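Branched alkyl replacing phenethyl in a quinoline-based series

The source may hold more compounds than are shown below. What is called first, only, known or untested is meant among the compounds shown, and "the series" means these compounds.

Measured so far:
Compound 1, `CC(C)CCc1ccc2c(NCCCNCc3ccco3)ccnc2c1`: 11200 nM
Compound 2, `FC(F)(F)c1ccc(-c2ccc3c(NCCCNCc4ccco4)ccnc3c2)cc1`: 3470 nM
Compound 3, `c1ccc(CCc2ccc3c(NCCCNCc4ccco4)ccnc3c2)cc1`: 16000 nM

In an ADME assay on HepG2 cells (Homo sapiens) for cytotoxicity, read by luminescence, CellTiter-Glo and ATP content, with a stated time of 72 h (a higher number here means that more compound is needed for the effect, a lower number that less compound is needed), compound 3 gives the highest of the three numbers; its gap to compound 1 lies within the scatter, while the step of a 4.6-fold higher number from compound 2 to compound 3 (0.66 log units; beyond the scatter) stands beyond it. Compound 4, `CCC(CC)c1ccc2c(NCCCNCc3ccco3)ccnc2c1`, carries pentan-3-yl in place of phenethyl on an aromatic carbon. The step that bears most on this change is a 1.4-fold higher number from compound 1 to compound 3 (0.15 log units; within the scatter), which exchanged a phenyl on the chain for a branched alkyl without moving beyond the scatter; the step of a 3.2-fold lower number from compound 1 to compound 2 (0.51 log units; beyond the scatter) shows that an aryl group directly on the ring gave a lower number, but compound 4 has no ring in its new group. Compound 4 is therefore expected to show a 1.2-fold lower number from compound 3 to compound 4 (0.09 log units; within the scatter). The value of compound 4 in this assay is estimated at 13000 nM, within the range 5500 nM to 30000 nM.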

Compound 4, half-maximal effective concentration: 6760 nM
The estimate for compound 4 lay 1.9-fold (0.28 log units) above the measured number; the range from low to high includes it.
By their numbers in this assay, from the lowest: compounds 2, 4, 1 and 3 (each within the scatter of the next, the first and the last beyond it).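

In this assay, pentan-3-yl in place of phenethyl at this position gives a 2.4-fold lower number from compound 3 to compound 4 (0.37 log units; beyond the scatter), so here a group with no ring separates from phenethyl, which isopentyl did not do. Pentan-3-yl does not separate from isopentyl, with a 1.7-fold lower number from compound 1 to compound 4 (0.22 log units; within the scatter), or from 4-(trifluoromethyl)phenyl, with a 1.9-fold higher number from compound 2 to compound 4 (0.29 log units; within the scatter), although phenethyl and 4-(trifluoromethyl)phenyl do differ beyond the scatter. Nothing available explains these steps. The compounds shown leave open how a cyclohexyl ring, a shorter chain or an amine would read at this position.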